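A Methyl Added to a Compound at the Limit

The source may hold more compounds than are shown below. What is called first, only, known or untested is meant among the compounds shown, and "the series" means these compounds.

Values in a functional assay on HT-29 cells (Homo sapiens) for antiproliferative activity, read by sulforhodamine B assay, with a stated time of 48 h; a lower number here means a stronger inhibitor, a higher number a weaker inhibitor:
- compound 1 `CN1CCN(c2ccc(S(=O)(=O)Oc3cccc(Br)c3)cc2)C1=O`: 1300 nM
- compound 2 `CN1CCN(c2ccc(S(=O)(=O)Oc3cccc(I)c3)cc2)C1=O`: 590 nM
- compound 3 `COc1ccc(OS(=O)(=O)c2ccc(N3CCN(C)C3=O)cc2)cc1`: > 100000 nM (a limit of the assay, not a number)

Compound 3 stands at the limit of > 100000 nM in this assay, at which 1 of the 3 values shown sits. The next compound, compound 4 `CCN1CCN(c2ccc(S(=O)(=O)Oc3ccc(OC)cc3)cc2)C1=O`, differs from it by a single change: methyl in place of hydrogen on a saturated chain carbon bound to an amide-type nitrogen in a ring. In other words, methyl takes the place of hydrogen on a saturated chain carbon bound to an amide-type nitrogen in a ring, turning 3-methyl-2-oxoimidazolidin-1-yl into 3-ethyl-2-oxoimidazolidin-1-yl.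

Among the measured compounds shown here, no measured step touches this group. The large steps, an at least 76-fold higher number from compound 1 to compound 3 (1.88 log units; beyond the scatter) and an at least 160-fold higher number from compound 2 to compound 3 (2.22 log units; beyond the scatter), both come from placing 4-methoxyphenyl on the oxygen, and compound 4 keeps that group. For the measured compounds named here, the only other step, a 2.2-fold lower number from compound 1 to compound 2 (0.34 log units; beyond the scatter), is modest and concerns the halogen. The two large steps therefore say where compound 4 is likely to start, but not what the added methyl will do.

In this assay, no step beyond the scatter is expected in either direction, and the assay will quite possibly report only a limit again. The expected outcome is a number no higher from compound 3 to compound 4 (the limit leaves the size open). For compound 4 the estimated value is 100000 nM, with an expected range of 30000 nM to 300000 nM.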

Compound 4, half-maximal inhibitory concentration: 60000 nM
Compound 4: the middle estimate sits 1.7-fold (0.22 log units) above what was measured; the range from low to high includes it.
By their numbers in this assay, from the lowest: compound 2; then compound 1; then compound 4. At a limit, above all of these: compound 3.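

In this assay, among the compounds shown here, compound 4 gives 60000 nM, the only measured value so far for a compound changed at this saturated chain carbon bound to an amide-type nitrogen in a ring. Compound 3, by contrast, is held at a limit of the assay and has no number of its own: the limit of > 100000 nM in this assay, at which 1 of the 4 values shown sits.

From the compounds shown here alone, the comparison can therefore be read only as a floor, an at least 1.6-fold lower number from compound 3 to compound 4 (0.22 log units; that floor lies within the scatter), so the change from 3-methyl-2-oxoimidazolidin-1-yl to 3-ethyl-2-oxoimidazolidin-1-yl brings a compound carrying 4-methoxyphenyl on the oxygen to a measurable value, while the true size of the step remains unknown and the floor alone shows no change beyond the scatter.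

The compounds shown leave open whether a longer chain such as propyl, or a chain ending in an amine, would give a value in the same range at this place. They also leave open what the added methyl does when 3-bromophenyl or 3-iodophenyl sits on the oxygen, since the ethyl group appears here only together with 4-methoxyphenyl.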